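Methoxy in Place of Fluoro: Compound 3 to Compound 4

A few compounds are considered here, and "the series" means these few. Any claim that something is new, unique, unknown or untested is made for them only; others in the source may bear on it.

Compound 3 `N#C/C(=C\c1c[nH]c2cc(F)ccc12)C(=O)c1c[nH]c2cc(F)ccc12` reaches only the limit of > 50000 nM in a functional assay on PC-3 cells (Homo sapiens) for cytotoxicity, read by WST assay, with a stated time of 24 h (on this read-out lower numbers stand for stronger inhibition and higher numbers for weaker inhibition), so no number stands for it. Compound 1 `COc1ccc2c(/C=C(\C#N)C(=O)c3c[nH]c4cc(OC)ccc34)c[nH]c2c1` likewise stops at the limit of > 50000 nM in this assay. Within the data shown here, compound 2 `COc1ccc2c(C(=O)/C(C#N)=C/c3c[nH]c4cc(F)ccc34)c[nH]c2c1` gives 36000 nM in this assay, the one real number among the three. The change to compound 4 `COc1ccc2c(/C=C(\C#N)C(=O)c3c[nH]c4cc(F)ccc34)c[nH]c2c1` is methoxy in place of fluoro on an aromatic carbon. Among the measured compounds shown here, two measured steps bear on it, both running the opposite way: an at least 1.3-fold lower number from compound 1 to compound 2 (0.14 log units; that floor lies within the scatter) and an at least 1.3-fold higher number from compound 2 to compound 3 (0.14 log units; that floor lies within the scatter), and each rests on a limit of > 50000 nM in this assay, at which 2 of the 3 values shown sit, rather than on two numbers. Neither leaves the scatter, so no clear direction can be drawn from them. Compound 4 is therefore expected to sit near the limit again, estimated at 45000 nM with a range from 20000 nM to 100000 nM, corresponding to an at least 1.1-fold lower number from compound 3 to compound 4 (0.04 log units; that floor lies within the scatter).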

Compound 4, half-maximal inhibitory concentration: > 50000 nM
Compound 4 gave a limit, no number (the forecaster's own chance of this, stated with the estimate: 60%); at least 1.1-fold (0.04 log units) between middle value and limit.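

Compound 4 also ends at a limit, so its steps from compound 3 and from compound 1 cannot be read: the limit of > 50000 nM in this assay, at which 3 of the 4 values shown sit. The compounds shown leave open whether methoxy in place of fluoro on an aromatic carbon changes anything in this assay.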